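The source may report more compounds than this note shows. Statements on the series, on what has been measured and on what is new or still open speak of the compounds shown alone.

Measured in a functional assay on SGC-7901 cells (Homo sapiens) for cytotoxicity, read by MTT assay, with a stated time of 48 h; a higher number here means a weaker inhibitor, a lower number a stronger inhibitor:

- Compound 1 `O=C(CSc1ccccc1)N1N=C(c2cc3ccccc3oc2=O)C[C@@H]1c1ccccc1` gives 20300 nM
- Compound 2 `CC1=NN(C(=O)CSc2ccccn2)[C@@H](c2cc(Br)cc(Br)c2O)C1` gives 10300 nM
- Compound 3 `O=C(CSc1ccc([N+](=O)[O-])cc1)N1N=C(c2cc3ccccc3oc2=O)C[C@@H]1c1ccccc1C(F)(F)F` gives 9770 nM

Compound 3 at 9770 nM holds the lowest number of the three, but it lies within the scatter of compound 2 at 10300 nM. Only compound 1 at 20300 nM stands apart from compound 3 by more than the scatter, with a higher number.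

The next compound to be tested in this assay is compound 4 `O=C(CSCc1ccco1)N1N=C(c2cc3ccccc3oc2=O)C[C@@H]1c1ccccc1C(F)(F)F`. It keeps the rest of compound 3 and carries (furan-2-yl)methyl in place of 4-nitrophenyl on a sulfur, a difference that counts as (furan-2-yl)methyl in place of 4-nitrophenyl on a sulfur here.

Among the measured compounds shown here, no pair of measured compounds differs in one place only, so the data show nothing directly about this exchange. The expectation rests on the narrow range of the measured values, whose highest is held by compound 1 at 20300 nM. A large step therefore seems unlikely, and a modest rise in the number is the more likely outcome, though one that may stay close to the scatter. The expected size of the change is a 1.4-fold higher number from compound 3 to compound 4 (0.16 log units; within the scatter). Compound 4 is estimated at 14000 nM, with an expected range of 6000 nM to 32000 nM.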

Compound 4, half-maximal inhibitory concentration: 10300 nM
Compound 4: the middle estimate sits 1.4-fold (0.13 log units) above what was measured; measured number inside the range.
By their numbers in this assay, from the lowest: compounds 3, 2, 4 and 1 (each within the scatter of the next, the first and the last beyond it).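

In this assay, the exchange of 4-nitrophenyl for (furan-2-yl)methyl on a sulfur gives a 1.1-fold higher number from compound 3 to compound 4 (0.02 log units; within the scatter) and is the only comparison among these compounds that isolates a single place. It shows that this sulfur substituent can differ considerably without moving the read-out beyond the scatter: the six-membered aromatic ring of carbon with its nitro group gives way to a five-membered aromatic ring with one hetero atom, carried on a saturated carbon, while the heavy atoms of the group go from 9 to 6 and its hydrogen-bond acceptors from 2 to 1. Nothing available explains why the two compounds read alike, so the result stands as an observation only.

This single pair cannot show whether the same holds for very different groups on the sulfur, such as an amine, a carboxylic acid or a longer saturated chain bearing the furan. It also leaves open whether any group at this place could move the number beyond the scatter in either direction, and whether the exchange would behave the same way on a core without the trifluoromethyl group.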